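Nitro in place of hydroxy: notes on the series

This account rests on a few compounds, and the source may have more. Where it says the series, first, only, none or still open, it means among the compounds named here.

Measured in a functional assay on A549 cells (Homo sapiens) for antiproliferative activity, read by sulforhodamine B assay, with a stated time of 48 h; on this read-out higher numbers stand for weaker inhibition and lower numbers for stronger inhibition:
- compound 1 `COc1cc(OC)c2sc(-c3ccc(N/C=C\C(=O)c4ccc(OC)c([N+](=O)[O-])c4)c(C)c3)nc2c1`: 12100 nM
- compound 2 `COc1cc(OC)c2sc(-c3ccc(N/C=C\C(=O)c4ccc(OC)c(O)c4)cc3)nc2c1`: 10600 nM

Compound 2 stands within the scatter of compound 1, so the two numbers give no order. The next compound to be measured is compound 3 `COc1cc(OC)c2sc(-c3ccc(N/C=C\C(=O)c4ccc(OC)c([N+](=O)[O-])c4)cc3)nc2c1`. It follows from compound 2 by nitro in place of hydroxy on an aromatic carbon, which is nitro in place of hydroxy on an aromatic carbon, ortho to a methoxy group. For the measured compounds named here, no measured pair isolates this change, and compound 1, the only measured compound with the 4-methoxy-3-nitrophenyl group, also differs from compound 3 elsewhere. Even so, compound 1 at 12100 nM gives no hint that this group departs from the 3-hydroxy-4-methoxyphenyl group of compound 2 at 10600 nM. An estimated 1.0-fold higher number from compound 2 to compound 3 (0.02 log units; within the scatter) is expected, with no change beyond the scatter in this assay. For compound 3 the expected value is 11000 nM, with an estimated range of 4500 nM to 25000 nM.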

Compound 3, half-maximal inhibitory concentration: 5800 nM
For compound 3 the middle estimate is 1.9-fold (0.28 log units) above the measured one, and the stated range covers the measured number.
By their numbers in this assay, from the lowest: compounds 3, 2 and 1 (each within the scatter of the next, the first and the last beyond it).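

In this assay, nitro in place of hydroxy, ortho to a methoxy group, now stands as an isolated change and gives a 1.8-fold lower number from compound 2 to compound 3 (0.26 log units; within the scatter); at this position the 3-hydroxy-4-methoxyphenyl and 4-methoxy-3-nitrophenyl groups therefore cannot be told apart beyond the scatter. For the compounds shown here, with the 4-methoxy-3-nitrophenyl group held constant, hydrogen in place of methyl on an aromatic carbon gives a 2.1-fold lower number from compound 1 to compound 3 (0.32 log units; beyond the scatter), the only single change in these compounds that reaches beyond the scatter. Nothing measured here accounts for either step.

Going by these compounds, it remains open how an amine or a carboxylic acid in place of the nitro group would read in this assay. On these data alone, it also remains open whether the methyl step would recur with the 3-hydroxy-4-methoxyphenyl group.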